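The source may hold more compounds than are shown below. What is called first, only, known or untested is meant among the compounds shown, and "the series" means these compounds.

Compound 3 `Cc1ccc(-n2c(-c3coc4cc(C)c(Cl)cc4c3=O)nc(-c3ccccc3)c2-c2ccccc2)cc1` gives 12500 nM in a functional assay on A549 cells (Homo sapiens) for inhibition, read by MTT assay, with a stated time of 72 h (on this read-out higher numbers stand for weaker inhibition and lower numbers for stronger inhibition), and stands level with compound 1 `Cc1cccc(-n2c(-c3coc4cc(C)c(Cl)cc4c3=O)nc(-c3ccccc3)c2-c2ccccc2)c1` at 12500 nM while compound 2 `Cc1ccc(-n2c(-c3coc4cc(C)c(Cl)cc4c3=O)nc(-c3ccccc3)c2-c2ccccc2)c(C)c1` gives 6250 nM and lies within the scatter of both. Going by the values given here, compound 4 `Cc1cc2occ(-c3nc(-c4ccccc4)c(-c4ccccc4)n3-c3cccc(Cl)c3)c(=O)c2cc1Cl` differs from compound 3 by having 3-chlorophenyl in place of 4-methylphenyl on an aromatic nitrogen and this group has not been measured on that nitrogen in any compound so far. Among the compounds with values here, the only guidance comes from the methylphenyl groups at that same place. Exchanging 3-methylphenyl for 4-methylphenyl gave no change at the digits printed from compound 1 to compound 3 (within the scatter) and exchanging it for 2,4-dimethylphenyl gave a 2.0-fold lower number from compound 1 to compound 2 (0.30 log units; within the scatter) while the return to a single methyl gave a 2.0-fold higher number from compound 2 to compound 3 (0.30 log units; within the scatter) and so none of these steps leaves the scatter. A step of similar small size is therefore expected, with no clear direction. The estimated change in this assay is a 1.3-fold lower number from compound 3 to compound 4 (0.10 log units; within the scatter) and it is expected to stay within the scatter. Compound 4 is expected to give about 10000 nM with 4000 nM to 25000 nM as its estimated range.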

Compound 4, half-maximal inhibitory concentration: 25000 nM
Beside the measured number, compound 4's estimate is 2.5-fold (0.40 log units) below it, within the range that was stated.
By their numbers in this assay, from the lowest: compounds 2, 1, 3 and 4 (each within the scatter of the next, the first and the last beyond it).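

In this assay, going by these compounds alone, 3-chlorophenyl on the aromatic nitrogen yields the first step at this position to go beyond the scatter: exchanging 2,4-dimethylphenyl for it gives a 4.0-fold higher number from compound 2 to compound 4 (0.60 log units; beyond the scatter), a modest difference. Against the groups with a single methyl, the same compound stays within the scatter, with a 2.0-fold higher number from compound 3 to compound 4 (0.30 log units; within the scatter) and, for chloro in place of methyl on an aromatic carbon, a 2.0-fold higher number from compound 1 to compound 4 (0.30 log units; within the scatter). Within the data shown here, nothing measured here accounts for the one step beyond the scatter.

The compounds shown leave open how 4-chlorophenyl or unsubstituted phenyl would compare on this nitrogen. They also leave open whether a group other than a substituted phenyl, such as a morpholine or a longer alkyl chain, would be accepted there, or how a carboxylic acid on the phenyl ring would read out.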